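Exchanging the Bicyclic Ring on the Sulfonyl Sulfur

The source may report more compounds than this note shows. Statements on the series, on what has been measured and on what is new or still open speak of the compounds shown alone.

Of the compounds shown here, two sharing one core have been measured in a functional assay on CHO cells for positive allosteric modulation of muscarinic acetylcholine receptor M5 (Homo sapiens), read by calcium flux; on this read-out higher numbers stand for larger maximal responses and lower numbers for smaller maximal responses. Compound 1 `CCN(Cc1ccccc1)C(=O)C1CCN(S(=O)(=O)c2cccc3c2OCCO3)CC1` carries a 2,3-dihydro-1,4-benzodioxin-5-yl group on its sulfonyl sulfur, and in this assay compound 1 gives 53%. Compound 2 `CCN(Cc1ccccc1)C(=O)C1CCN(S(=O)(=O)c2ccc3cn[nH]c3c2)CC1` carries 1H-indazol-6-yl at the same place; in this assay compound 2 gives 86%. The step of a number 33 percentage points higher from compound 1 to compound 2 (beyond the scatter) shows that the group on the sulfonyl sulfur can move the maximal response by a large amount. Of the two numbers, compound 2 stands highest, and compound 1 lies beyond the scatter below it.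

Compound 3 `CCN(Cc1ccccc1)C(=O)C1CCN(S(=O)(=O)c2ccc3nsnc3c2)CC1` has not yet been measured. It differs from compound 2 in one place: a group of 9 heavy atoms (6 carbon, 2 nitrogen, 1 sulfur; one five-membered aromatic ring with 3 hetero atoms, one six-membered aromatic ring of carbon only) in place of a group of 9 heavy atoms (7 carbon, 2 nitrogen; one five-membered aromatic ring with 2 hetero atoms, one six-membered aromatic ring of carbon only), on a sulfonyl sulfur. Among the compounds with values here, the only measured step at this place is a number 33 percentage points higher from compound 1 to compound 2 (beyond the scatter). Within the data shown here, that step was large, but it concerned a different pair of groups, so it shows only that exchanging the ring here can matter a great deal, not which way this particular exchange will go. With the hydrogen-bond donor of compound 2 gone, a moderate fall is expected, estimated as a number 21 percentage points lower from compound 2 to compound 3 (beyond the scatter). Compound 3 is therefore estimated at 65%, with a range from 40% to 90%.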

Compound 3, largest response reached (reported as percent of maximum), in percent of the reference or control that the assay uses: 81%
Beside the measured number, compound 3's estimate is 16 percentage points below it; the range from low to high includes it.
By their numbers in this assay, from the lowest: compound 1; then compounds 3 and 2 (each within the scatter of the next).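

Taking away the hydrogen-bond donor of 1H-indazol-6-yl does not lower the maximal response by any amount that can be read: the exchange on the sulfonyl sulfur gives a number 5 percentage points lower from compound 2 to compound 3 (within the scatter) in this assay, so at this position that donor is not required for a high response. The new group, with its five-membered aromatic ring holding sulfur and nitrogen, also stands clear of the 2,3-dihydro-1,4-benzodioxin-5-yl group, with a number 28 percentage points higher from compound 1 to compound 3 (beyond the scatter) as the step, which means that two different groups with a five-membered aromatic ring now sit above the one with a six-membered non-aromatic ring. Nothing measured here explains why the response holds up across this exchange or why compound 1 gives a smaller one.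

Still open, going by these compounds, is whether a second ring is needed at all, which a plain phenyl or pyridyl group on the sulfonyl sulfur could show. Also open, on these data alone, is how far a group such as an amine or a carboxylic acid on the ring would be tolerated, and how the concentration needed for the response compares, since this read-out gives only the largest response reached.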